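The compounds below may be only part of what the source reports. "The series", "measured", "known", "first", "only" and "open" are said of these compounds alone.

Within the data shown here, compound 3 `CC(C)c1onc(-c2c(Cl)cccc2Cl)c1COc1ccc(-c2nc3ccc(C(=O)O)cc3n2C2CCC2)cc1` gives 14.4 nM in an assay on Huh-7 cells for agonist activity at Bile acid receptor (Homo sapiens), read by a luciferase reporter (a higher number here means that more compound is needed for the effect, a lower number that less compound is needed), the highest of the three numbers measured so far. Compound 2 `CCn1c(-c2ccc(OCc3c(-c4c(Cl)cccc4Cl)noc3C(C)C)cc2)nc2ccc(C(=O)O)cc21` gives 2.31 nM, and compound 1 `CCC(CC)n1c(-c2ccc(OCc3c(-c4c(Cl)cccc4Cl)noc3C(C)C)cc2)nc2ccc(C(=O)O)cc21` gives 0.8 nM. The three differ only in the group on an aromatic nitrogen of the shared core, and every step among them lies beyond the scatter: a 2.9-fold higher number from compound 1 to compound 2 (0.46 log units; beyond the scatter), an 18-fold higher number from compound 1 to compound 3 (1.26 log units; beyond the scatter) and a 6.2-fold higher number from compound 2 to compound 3 (0.79 log units; beyond the scatter). Both open-chain groups, ethyl and pentan-3-yl, thus give lower numbers than the ring-shaped cyclobutyl.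

Compound 4 `CC(C)Cn1c(-c2ccc(OCc3c(-c4c(Cl)cccc4Cl)noc3C(C)C)cc2)nc2ccc(C(=O)O)cc21` carries isobutyl in place of cyclobutyl on an aromatic nitrogen. Isobutyl is an open chain like ethyl and pentan-3-yl, so the steps that bear on this change are those leading from the cyclobutyl group to the open-chain groups, read in reverse: a 6.2-fold higher number from compound 2 to compound 3 (0.79 log units; beyond the scatter) and an 18-fold higher number from compound 1 to compound 3 (1.26 log units; beyond the scatter). Among the measured compounds shown here, a lower number is therefore expected for compound 4 in this assay, by a step of at least modest size, although no measured compound tells how a branched chain of this shape compares with ethyl or pentan-3-yl. The expected step is a 5.8-fold lower number from compound 3 to compound 4 (0.76 log units; beyond the scatter). For compound 4 the expected value is 2.5 nM, with a range from 0.8 nM to 8 nM.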

Compound 4, half-maximal effective concentration: 5.26 nM
Beside the measured number, compound 4's estimate is 2.1-fold (0.32 log units) below it; low and high end bracket the measured number.
By their numbers in this assay, from the lowest: compound 1; then compound 2; then compound 4; then compound 3.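

Cyclobutyl and isobutyl have the same count of heavy atoms, all carbon, so this pair separates ring from open chain at equal count, and in this assay opening the ring gives a 2.7-fold lower number from compound 3 to compound 4 (0.44 log units; beyond the scatter). Having an open chain is not the whole story, though, since putting isopropyl in place of methyl on the saturated chain carbon bound to the aromatic nitrogen gives a 2.3-fold higher number from compound 2 to compound 4 (0.36 log units; beyond the scatter), and isobutyl in place of pentan-3-yl gives a 6.6-fold higher number from compound 1 to compound 4 (0.82 log units; beyond the scatter). Among these four compounds the number therefore depends on the shape of the open chain as well, with isobutyl falling between cyclobutyl and the other two open chains, and no measurement at hand explains why this is so.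

Going by these compounds, with cyclobutyl as the only ring at this position, it remains open whether a cyclopropyl or cyclohexyl group would also give a higher number than the open chains. It is equally unknown how a straight propyl chain, or a chain carrying an oxygen such as 2-methoxyethyl, would compare with ethyl and isobutyl.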